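From dichlorophenyl to difluorophenyl on the carbonyl carbon

The source may hold more compounds than are shown below. What is called first, only, known or untested is meant among the compounds shown, and "the series" means these compounds.

Compound 1 `CN(C(=O)NC(=O)c1ccc(F)c(F)c1)c1nc(C(F)(F)F)c(C(=O)N/N=C/c2ccc(C(F)(F)F)cc2)s1` gives 6.26 ug/mL in a functional assay on HepG2 cells (Homo sapiens) for inhibition, read by MTT assay, with a stated time of 72 h; a higher number here means a weaker inhibitor, a lower number a stronger inhibitor.
Compound 2 `CN(C(=O)NC(=O)c1ccc(F)c(F)c1)c1nc(C(F)(F)F)c(C(=O)N/N=C/c2ccccc2C(F)(F)F)s1` gives 10.4 ug/mL in this assay.
Compound 3 `CN(C(=O)NC(=O)c1ccc(Cl)c(Cl)c1)c1nc(C(F)(F)F)c(C(=O)N/N=C/c2ccc([N+](=O)[O-])cc2)s1` gives 6.85 ug/mL in this assay.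

Compound 3 stands second highest of the three numbers. Its nearest neighbour is compound 1, its furthest compound 2, and both of those gaps lie within the scatter of repeated measurements, so the three compounds form a single band rather than an order.

Compound 4 `CN(C(=O)NC(=O)c1ccc(F)c(F)c1)c1nc(C(F)(F)F)c(C(=O)N/N=C/c2ccc([N+](=O)[O-])cc2)s1` has not yet been measured in this assay. It differs from compound 3 in one place: 3,4-difluorophenyl in place of 3,4-dichlorophenyl on a carbonyl carbon. For the measured compounds named here, no measured step bears directly on this part of the molecule. Going by the values given here, the only measured step, a 1.7-fold higher number from compound 1 to compound 2 (0.22 log units; within the scatter), concerns the group on the carbon with a double bond to nitrogen and lies within the scatter. What the data do show is that compounds 1 and 2, which already carry the 3,4-difluorophenyl group that enters here, sit in the same band as compound 3. The account therefore expects no step beyond the scatter, a 1.0-fold higher number from compound 3 to compound 4 (0.01 log units; within the scatter). Compound 4 is estimated at 7 ug/mL, with a range from 3.5 ug/mL to 14 ug/mL.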

Compound 4, half-maximal inhibitory concentration: 6.23 ug/mL
Compound 4: the middle estimate sits 1.1-fold (0.05 log units) above what was measured; measured number inside the range.
By their numbers in this assay, from the lowest: compounds 4, 1, 3 and 2 (each within the scatter of the next).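

In this assay the 3,4-difluorophenyl group in place of the 3,4-dichlorophenyl group on the carbonyl carbon, with the 4-nitrophenyl group held fixed, gives a direct reading at this position (a 1.1-fold lower number from compound 3 to compound 4 (0.04 log units; within the scatter)), and the two groups cannot be told apart here. With the 3,4-difluorophenyl group held fixed, the group on the carbon with a double bond to nitrogen can also be read in two further steps, nitro in place of trifluoromethyl on an aromatic carbon (a 1.0-fold lower number from compound 1 to compound 4 (0.00 log units; within the scatter)) and 4-nitrophenyl in place of 2-(trifluoromethyl)phenyl (a 1.7-fold lower number from compound 2 to compound 4 (0.22 log units; within the scatter)), and neither goes beyond the scatter. No measurement is at hand that would explain these readings.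

The compounds shown leave open what the number does when the carbonyl carbon carries a phenyl ring with no halogen, or a cyclohexyl ring or a longer alkyl chain in place of the phenyl ring. As far as these compounds go, the 3,4-dichlorophenyl group also appears here only together with the 4-nitrophenyl group, so its reading alongside 4-(trifluoromethyl)phenyl or 2-(trifluoromethyl)phenyl remains unknown.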